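Dropping the butylsulfonylamino group from compound 3

This account rests on a few compounds, and the source may have more. Where it says the series, first, only, none or still open, it means among the compounds named here.

Values in a functional assay for inhibition, with Homo sapiens as the target (on this read-out higher numbers stand for weaker inhibition and lower numbers for stronger inhibition), for the measured compounds:
Compound 1 `O=C(NC[C@H](NS(=O)(=O)c1cccnc1)C(=O)O)c1cc2cc(CCC3CCNCC3)sc2s1` gives 8 nM
Compound 2 `O=C(NC[C@H](NS(=O)(=O)c1ccc(Cl)cc1)C(=O)O)c1cc2cc(CCC3CCNCC3)sc2s1` gives 11 nM
Compound 3 `CCCCS(=O)(=O)N[C@@H](CNC(=O)c1cc2cc(CCC3CCNCC3)sc2s1)C(=O)O` gives 32 nM

Compound 3 has the highest number of the three, which makes it the weakest inhibitor here, and both of its steps lie beyond the scatter (a 2.9-fold higher number from compound 2 to compound 3 (0.46 log units; beyond the scatter)) and (a 4.0-fold higher number from compound 1 to compound 3 (0.60 log units; beyond the scatter)). Compound 4 `O=C(O)CCNC(=O)c1cc2cc(CCC3CCNCC3)sc2s1` is still unmeasured. It differs from compound 3 by hydrogen in place of (butylsulfonyl)amino on a saturated chain carbon bound to a carbonyl carbon and a saturated chain carbon.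

The three measured steps bear on this change only indirectly, since each swaps just the group on the sulfonyl sulfur. Exchanging the two ring groups stayed within the scatter (a 1.4-fold higher number from compound 1 to compound 2 (0.14 log units; within the scatter)), while butyl gave the two modest rises already shown. Among the compounds with values here, no measured compound lacks the sulfonyl group altogether, so the size of this larger change is uncertain. Compound 4 loses the whole group, so a rise at least as large as those modest steps seems likely. Compound 4 is expected to move upward by an estimated 3.8-fold higher number from compound 3 to compound 4 (0.57 log units; beyond the scatter) on this scale. Compound 4 is estimated at 120 nM with an expected range of 35 nM to 420 nM in this assay when it is measured.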

Compound 4, half-maximal inhibitory concentration: 410 nM
Compound 4: the middle estimate sits 3.4-fold (0.53 log units) below what was measured, and the stated range covers the measured number.
By their numbers in this assay, from the lowest: compounds 1 and 2 (each within the scatter of the next); then compound 3; then compound 4.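

In this assay, the earlier swaps on the sulfonyl sulfur were modest or within the scatter, but taking away the whole (butylsulfonyl)amino group and leaving hydrogen on the saturated chain carbon gives a 13-fold higher number from compound 3 to compound 4 (1.11 log units; beyond the scatter) and is a far larger loss. Measured against the aromatic sulfonyl compounds, the same removal gives a 37-fold higher number from compound 2 to compound 4 (1.57 log units; beyond the scatter) and a 51-fold higher number from compound 1 to compound 4 (1.71 log units; beyond the scatter) and leaves compound 4 as the weakest inhibitor of the four. This shows that the choice of group on the sulfur only tunes the result, while having a sulfonylamino group at this position at all accounts for much more, and even the butyl version keeps a large part of that gain.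

From the compounds shown here alone, what remains open is which part of the removed group matters. A plain amino group on that carbon would test the nitrogen without the sulfonyl part, and an acetylamino group would test whether a carbonyl can stand in for the sulfonyl. No measurement at hand explains the size of this loss.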